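Heteroaryl swaps on the shared core in HL-60 growth

The source may report more compounds than this note shows. Statements on the series, on what has been measured and on what is new or still open speak of the compounds shown alone.

Compound 1 `Nc1nc(N)c2c(-c3ccsc3)cn([C@@H]3O[C@H](CO)[C@@H](O)[C@H]3O)c2n1` carries a thiophen-3-yl group on the shared core. In a functional assay on HL-60 cells (Homo sapiens) for antiproliferative activity, read by XTT assay, with a stated time of 72 h (a higher number here means a weaker inhibitor, a lower number a stronger inhibitor), compound 1 gives only a limit, > 20000 nM. Compound 2 `COc1nc(N)nc2c1c(-c1cc3ccccc3o1)cn2[C@@H]1O[C@H](CO)[C@@H](O)[C@H]1O` carries 1-benzofuran-2-yl and a methoxy group. In this assay compound 2 likewise gives a limit, > 20000 nM. Compound 3 `Nc1nc(N)c2c(-c3cc4ccccc4o3)cn([C@@H]3O[C@H](CO)[C@@H](O)[C@H]3O)c2n1` carries 1-benzofuran-2-yl with an amino group. In this assay compound 3 also gives a limit, > 15000 nM. Compound 3 thus sits at the limit of > 15000 nM in this assay, at which 1 of the 3 values shown sits, the other two at the limit of > 20000 nM in this assay, at which 2 of the 3 values shown sit, and the steps a step that the two limits leave unreadable from compound 1 to compound 3 and a step that the two limits leave unreadable from compound 2 to compound 3 have no readable size. Compound 4 `Nc1nc(N)c2c(-c3ccoc3)cn([C@@H]3O[C@H](CO)[C@@H](O)[C@H]3O)c2n1` differs by furan-3-yl in place of 1-benzofuran-2-yl on an aromatic carbon. Among the measured compounds shown here, no measured step bears readably on this change. The step that the limit leaves unreadable from compound 3 to compound 4 is therefore estimated as nothing beyond the scatter, with another limit most likely. Compound 4 is expected at 25000 nM, within 10000 nM to 60000 nM.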

Compound 4, half-maximal inhibitory concentration: > 20000 nM
Compound 4 ended at the assay's limit (the forecaster's own chance of this, stated with the estimate: 85%); the middle value does not contradict the limit.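

Compound 4, like compound 1 and compound 3, stands only at a limit, so the steps to compound 4 cannot be read. The compounds shown leave open how furan-3-yl, thiophen-3-yl and 1-benzofuran-2-yl rank on the shared core.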